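Swapping Phenoxy for Dimethylamino: Expected Effect on Cell Tolerance

The source may hold more compounds than are shown below. What is called first, only, known or untested is meant among the compounds shown, and "the series" means these compounds.

Of the compounds shown here, two have so far been measured in a functional assay on NCI-H460 cells (Homo sapiens) for inhibition, read by sulforhodamine B assay, with a stated time of 48 h; a lower number here means that less compound is tolerated, a higher number that more compound is tolerated. Compound 1 `COc1cc(C)cc(-c2nn(CC#N)cc2-c2ccc(-c3cccc(C(C)=O)c3)nc2)c1` gives 26600 nM in this assay. Compound 2 `Cc1cc(O)cc(-c2nn(CC#N)cc2-c2ccnc(-c3ccc(Oc4ccccc4)cc3)c2)c1` gives 6850 nM in this assay. Of these two numbers, compound 2 holds the lower one, and the gap to compound 1 is wider than the scatter of repeated measurements, so the cells tolerate less of compound 2 than of compound 1. These two compounds differ from each other in several places at once, so no single structural change can be tied to that gap.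

Compound 3 `Cc1cc(O)cc(-c2nn(CC#N)cc2-c2ccnc(-c3ccc(N(C)C)cc3)c2)c1` has not been measured. It differs from compound 2 in one place only: dimethylamino in place of phenoxy on an aromatic carbon. Going by the values given here, nothing among the measured compounds shows what this particular exchange does to the number, so the expected step from compound 2 to compound 3 is a small one, a 1.2-fold higher number from compound 2 to compound 3 (0.07 log units; within the scatter), with a wide margin on either side. For compound 3 in this assay the estimate is 8000 nM, with a range from 2000 nM to 30000 nM.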

Compound 3, concentration lethal to 50% of the cells: 70500 nM
Beside the measured number, compound 3's estimate is 8.8-fold (0.95 log units) below it, outside the stated range (above it).
By their numbers in this assay, from the lowest: compound 2; then compound 1; then compound 3.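

The exchange of phenoxy for dimethylamino, on an aromatic carbon para to a large group, gives a 10-fold higher number from compound 2 to compound 3 (1.01 log units; beyond the scatter) in this assay, so the cells tolerate far more of compound 3 than of compound 2. Going by these compounds alone, this is the first change in the set made in one place only, and it shows that this position is not indifferent: with the rest of the molecule unchanged, the group placed there moves the number well beyond the scatter, even though a six-membered aromatic ring of carbon only leaves and a smaller group with no ring enters. No measurement of any property of these two groups is available to show which part of the exchange carries the step.

A methoxy group, a methylamino group or a morpholine ring at the same place could show whether the number depends on losing the aromatic ring, on the oxygen giving way to nitrogen, or on the size of the group. This single pair also leaves open whether the same exchange would give a step of similar size on a different core.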